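A few compounds are considered here, and "the series" means these few. Any claim that something is new, unique, unknown or untested is made for them only; others in the source may bear on it.

Measured in a functional assay on HeLa cells (Homo sapiens) for cytotoxicity, read by sulforhodamine B assay, with a stated time of 48 h; a higher number here means a weaker inhibitor, a lower number a stronger inhibitor:
Compound 1 `COc1ccc2c(c1)c(C=O)cn2Cc1cn([C@@H]2O[C@H](COC(C)=O)[C@@H](OC(C)=O)[C@H](OC(C)=O)[C@H]2OC(C)=O)nn1` gives only a limit, > 200000 nM.
Compound 2 `COc1ccc2c(c1)c(/C=N/O)cn2Cc1cn([C@@H]2O[C@H](COC(C)=O)[C@@H](OC(C)=O)[C@H](OC(C)=O)[C@H]2OC(C)=O)nn1` gives only a limit, > 200000 nM.
Compound 3 `COc1ccc(/C=C2\C(=O)N(Cc3cn([C@@H]4O[C@H](COC(C)=O)[C@@H](OC(C)=O)[C@H](OC(C)=O)[C@H]4OC(C)=O)nn3)c3ccccc32)cc1OC` gives 63400 nM.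

Compound 3 is thus the only one of the three with a number in this assay; the other two sit at a limit (the limit of > 200000 nM in this assay, at which 2 of the 3 values shown sit). Among the compounds with values here, the single step computed between measured compounds, a step that the two limits leave unreadable from compound 1 to compound 2, concerns a different change on the shared core and cannot be read, so no measured step bears on the change from compound 3 to compound 4 `CCC/C=C1\C(=O)N(Cc2cn([C@@H]3O[C@H](COC(C)=O)[C@@H](OC(C)=O)[C@H](OC(C)=O)[C@H]3OC(C)=O)nn2)c2ccccc21`. That change is propyl in place of 3,4-dimethoxyphenyl on a double-bonded chain carbon bound to a double-bonded ring carbon. Compound 3 already lies near the limit, and the change removes the larger group without any measured precedent for its effect. Compound 4 is therefore expected to be at best a weak inhibitor in this assay, estimated at 150000 nM with a range from 50000 nM to 400000 nM. The expected step from compound 3 to compound 4 is a 2.4-fold higher number from compound 3 to compound 4 (0.37 log units; beyond the scatter), and a reading that is only a limit is considered about as likely as a number.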

Compound 4, half-maximal inhibitory concentration: 46300 nM
Estimate against measurement, compound 4: 3.2-fold (0.51 log units) above; the measured number lies below the stated range.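

In this assay, replacing 3,4-dimethoxyphenyl with propyl on a double-bonded chain carbon bound to a double-bonded ring carbon gives a 1.4-fold lower number from compound 3 to compound 4 (0.14 log units; within the scatter). Within the data shown here, this is the first step that can be read, and it shows that this place accepts a large change in group with no change in the number beyond the scatter. An aromatic ring and its two oxygen-bearing methoxy groups at this place are thus not required for a measurable number, since compound 4, with a plain propyl chain, still gives one.

As far as these compounds go, it remains open whether an amine, a carboxylic acid or a longer chain at this place would move the number beyond the scatter. Compound 1 and compound 2 each give only a limit, so the step between them cannot be read: the limit of > 200000 nM in this assay, at which 2 of the 4 values shown sit.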